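Chloro for isopropoxy on the biaryl: an untested swap

The compounds below may be only part of what the source reports. "The series", "measured", "known", "first", "only" and "open" are said of these compounds alone.

Measured compounds:
compound 1, `CC(C)Oc1cccc(-c2ccc(C(=O)N(Cc3cccc(OCCCCCC(=O)O)c3)C(C)C)cc2)c1`: > 26000 nM
compound 2, `CC(C)N(Cc1cccc(OCCCCCC(=O)O)c1)C(=O)c1ccc(-c2ccc3c(c2)OCCO3)cc1`: > 21900 nM
compound 3, `CCOC(=O)CCCCCOc1cccc(CN(C(=O)c2ccc(-c3cccc(OC(C)C)c3)cc2)C(C)C)c1`: > 26000 nM

In an ADME assay on Raji cells (Homo sapiens) for cytotoxicity, read by CellTiter-Glo and resazurin assay, with a stated time of 72 h (a lower number here means that less compound is needed, a higher number that more compound is needed for the effect), compound 3 gives only a limit, > 26000 nM, and no number. Compound 1 likewise gives only a limit, > 26000 nM. Compound 2 also gives only a limit, > 21900 nM. Compound 3 therefore stands at the limit of > 26000 nM in this assay, at which 2 of the 3 values shown sit, alongside compound 1, while compound 2 stands at the limit of > 21900 nM in this assay, at which 1 of the 3 values shown sits. The step that the two limits leave unreadable from compound 1 to compound 3 cannot be read, and neither can the step that the two limits leave unreadable from compound 1 to compound 2.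

Compound 4, `CCOC(=O)CCCCCOc1cccc(CN(C(=O)c2ccc(-c3cccc(Cl)c3)cc2)C(C)C)c1`, differs from compound 3 by chloro in place of isopropoxy on an aromatic carbon. No measured step touches this exchange, and the two steps that are shown are themselves unreadable. Nothing in the three compounds hints at a readable number below the limit, so compound 4 is expected to give a limit again, with an estimated step that the limit leaves unreadable from compound 3 to compound 4 that cannot be sized. For compound 4 the estimate in this assay is 30000 nM, in a range from 10000 nM to 100000 nM.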

Compound 4, half-maximal effective concentration: > 18400 nM
Compound 4: only a limit was reported; the forecaster's own chance of this, stated with the estimate: 80%; the middle value does not contradict the limit.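

Compound 3 and compound 4 each give only a limit, so the step between them, chloro in place of isopropoxy, cannot be read. The compounds shown leave open whether any of them would give a readable value rather than a limit.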